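The source may report more compounds than this note shows. Statements on the series, on what has been measured and on what is new or still open speak of the compounds shown alone.

Working notes on the series in a functional assay on SH-SY5Y cells (Homo sapiens) for cytotoxicity, read by MTT assay, with a stated time of 72 h; on this read-out lower numbers stand for stronger inhibition and higher numbers for weaker inhibition.

Compound 1 `O=C1c2c[n+]([O-])c3ccccc3c2C(=O)c2c1c1ccccc1n2Cc1cn([C@H]2O[C@H](CO)[C@@H](O)[C@H]2O)nn1` gives 1340 nM in this assay. Compound 3 `O=C1c2c[n+]([O-])c3ccccc3c2C(=O)c2c1c1ccccc1n2Cc1cn([C@H]2C[C@H](O)[C@@H](CO)O2)nn1` gives 620 nM, and the change from compound 1 to compound 3, 4-hydroxy-5-(hydroxymethyl)oxolan-2-yl in place of 3,4-dihydroxy-5-(hydroxymethyl)oxolan-2-yl on an aromatic nitrogen, gives a 2.2-fold lower number from compound 1 to compound 3 (0.33 log units; beyond the scatter). Compound 2 `O=C1c2c[n+]([O-])c3ccccc3c2C(=O)c2c1c1ccccc1n2Cc1cn(CC(O)CO)nn1` is known in this assay only as a limit, > 1000 nM, the limit being (the limit of > 1000 nM in this assay, at which 1 of the 3 values shown sits). Compound 2 therefore stands at no fixed place among the three; the step from compound 2 to compound 3 is an at least 1.6-fold lower number from compound 2 to compound 3 (0.20 log units; that floor lies within the scatter) and the step from compound 1 to compound 2 is a step that the limit leaves unreadable from compound 1 to compound 2.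

Compound 4 `CN1CCN(CCCCCCn2c3c(c4ccccc42)C(=O)c2c[n+]([O-])c4ccccc4c2C3=O)CC1` is not yet measured. It differs from compound 2 at one place: 5-(4-methylpiperazin-1-yl)pentyl in place of 1-(2,3-dihydroxypropyl)-1H-1,2,3-triazol-4-yl on a saturated chain carbon bound to an aromatic nitrogen. Going by the values given here, none of the measured steps exchanges the triazole-bearing group for a chain of this kind; all three vary only the substituent on the triazole nitrogen, and the measured values of compounds 1 and 3 lie close together. No direction beyond the scatter can be drawn from them for this change. The step from compound 2 to compound 4 is therefore estimated as an at least 1.1-fold lower number from compound 2 to compound 4 (0.04 log units; that floor lies within the scatter), with a wide range. Compound 4 is expected to give 900 nM, between 200 nM and 4000 nM.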

Compound 4, half-maximal inhibitory concentration: 920 nM
Beside the measured number, compound 4's estimate is 1.0-fold (0.01 log units) below it; low and high end bracket the measured number.
By their numbers in this assay, from the lowest: compounds 3, 4 and 1 (each within the scatter of the next, the first and the last beyond it).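

Unlike the earlier steps, which vary only the substituent on the triazole nitrogen, this change replaces the whole group on a saturated chain carbon bound to an aromatic nitrogen: in this assay compound 4, with 5-(4-methylpiperazin-1-yl)pentyl, gives 920 nM, so a measured number at this position does not depend on the 1-(2,3-dihydroxypropyl)-1H-1,2,3-triazol-4-yl group. The exchange gives an at least 1.0-fold lower number from compound 2 to compound 4 (0.03 log units; that floor lies within the scatter), and that floor fixes neither the size nor the direction of the change. Compound 2 is known here only as a limit: the limit of > 1000 nM in this assay, at which 1 of the 4 values shown sits.

The compounds shown leave open how the result divides between the 4-methylpiperazine ring and the pentyl chain. A 5-(morpholin-4-yl)pentyl group, or a butyl or hexyl chain carrying the same 4-methylpiperazin-1-yl ring, would separate the two.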